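The compounds below may be only part of what the source reports. "The series", "measured", "known", "first", "only" and "open" are said of these compounds alone.

Measured compounds:
compound 1 `O=C(O)CCCSCCN1C(=O)OC[C@@H]1/C=C/[C@@H](O)Cc1cccc(C(F)(F)F)c1` gives 1600 nM in an assay on CHO cells for displacement of a labelled ligand from prostaglandin E2 receptor EP3 subtype (Mus musculus), read by scintillation counting, with a stated time of 60 min; a lower number here means a stronger inhibitor, a higher number a weaker inhibitor
compound 2 `O=C(O)CCCSCCN1C(=O)OC[C@@H]1/C=C/[C@@H](O)Cc1cccc(-c2ccccc2)c1` gives > 10000 nM in this assay; this is a limit of the assay, not a number
compound 3 `O=C(O)CCCSCCN1C(=O)SC[C@@H]1/C=C/[C@@H](O)Cc1ccccc1` gives 39 nM in this assay

Compound 3 stands at the lowest of the two numbers reported; the nearest, compound 1, sits a long way higher, and the remaining value is a limit (the limit of > 10000 nM in this assay, at which 1 of the 3 values shown sits).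

Compound 4 `COCc1cccc(C[C@H](O)/C=C/[C@H]2CSC(=O)N2CCSCCCC(=O)O)c1` has not been measured. It differs from compound 3 in one place: methoxymethyl in place of hydrogen on an aromatic carbon.

Going by the values given here, only one measured step is available, and it concerns the same aromatic ring but on a different core and between two substituents rather than from hydrogen: an at least 6.2-fold higher number from compound 1 to compound 2 (0.79 log units; beyond the scatter). That step shows a larger aromatic group giving a higher number, but it starts from a trifluoromethyl, not from hydrogen, and the core of compound 1 carries an oxygen where compound 3 carries sulfur, so it bears on the present change only loosely.

On that basis a small move upward in this assay is expected for compound 4, possibly none beyond the scatter, from compound 3 as a 2.1-fold higher number from compound 3 to compound 4 (0.31 log units; beyond the scatter). The estimate for compound 4 is 80 nM, with a range from 20 nM to 400 nM.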

Compound 4, inhibition constant: > 10000 nM
Compound 4 gave a limit, no number; the forecaster's own chance of this, stated with the estimate: 5%; middle value at least 120-fold (2.09 log units) away from the limit.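

Replacing hydrogen with methoxymethyl on an aromatic carbon, meta to a large group, gives an at least 250-fold higher number from compound 3 to compound 4 (2.40 log units; beyond the scatter) in this assay. The earlier step ran between two substituents on a different core, so it left open how this position responds to a first substituent on the unsubstituted phenyl of compound 3; here a chain of only 3 heavy atoms, with no ring, is enough to take the series from a measured number to the end of the assay's range. The result for compound 4 is a limit, not a number, so the true size of the loss is not fixed, only its lower bound: the limit of > 10000 nM in this assay, at which 2 of the 4 values shown sit.

The compounds shown do not separate the contribution of the ether oxygen from that of the chain as a whole, and a methyl, a fluorine or a hydroxymethyl in the same place could still show whether any substituent here keeps a number near the 39 nM of compound 3. Also open, going by these compounds, is whether methoxymethyl would give the same outcome on the core of compound 1, or on another carbon of the ring.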